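Halogenated aryl ethers of a benzyl carbamate: a blank run

The source may hold more compounds than are shown below. What is called first, only, known or untested is meant among the compounds shown, and "the series" means these compounds.

The series shares a benzyl carbamate core, in which compound 1 `CCC(COc1ccccc1Cl)OC(=O)NCc1ccccc1`, compound 2 `CCC(COc1ccc(Cl)cc1)OC(=O)NCc1ccccc1` and compound 3 `CCC(COc1cccc(Br)c1)OC(=O)NCc1ccccc1` differ only in the halogen on the aryl ether. In an assay for inhibition of zeta-carotene desaturase, chloroplastic/chromoplastic (Capsicum annuum), using a Dixon plot, with a stated time of 8 h (on this read-out higher numbers stand for weaker inhibition and lower numbers for stronger inhibition), compound 1 reaches the limit of the assay, > 100000 nM. In this assay compound 2 also sits at the limit, > 100000 nM. In this assay compound 3 likewise gives only the limit, > 100000 nM. The steps a step that the two limits leave unreadable from compound 1 to compound 2, a step that the two limits leave unreadable from compound 1 to compound 3 and a step that the two limits leave unreadable from compound 2 to compound 3 therefore carry no readable size; all that is seen is the limit of > 100000 nM in this assay, at which 3 of the 3 values shown sit.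

Compound 4 `CCOC(=O)c1cccc(OCC(CC)OC(=O)NCc2ccccc2)c1` is not yet measured. It differs from compound 3 by ethoxycarbonyl in place of bromo on an aromatic carbon. Among the measured compounds shown here, no measured step speaks to this change: the three halogen exchanges that are measured were all unreadable, so no direction can be drawn from them. The working expectation for compound 4 in this assay is therefore that the value most likely stays at or near the limit again, with a step that the limit leaves unreadable from compound 3 to compound 4 as the step expected from compound 3 to compound 4. Compound 4 is estimated at 150000 nM, within a range from 30000 nM to 1000000 nM, and a limit rather than a number is the more likely outcome.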

Compound 4, half-maximal inhibitory concentration: > 100000 nM
Compound 4 was reported as a limit; the forecaster's own chance of this, stated with the estimate: 80%; the middle value does not contradict the limit.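

Compound 3 and compound 4 both give only a limit in this assay, so the step between them cannot be read: the limit of > 100000 nM in this assay, at which 4 of the 4 values shown sit.

The compounds shown leave open whether any change to the shared core would give a measurable value in this assay.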